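A few compounds are considered here, and "the series" means these few. Any claim that something is new, unique, unknown or untested is made for them only; others in the source may bear on it.

Measured so far in a functional assay on HepG2 cells (Homo sapiens) for antiproliferative activity, read by MTT assay, with a stated time of 48 h; a higher number here means a weaker inhibitor, a lower number a stronger inhibitor:
compound 1 `COc1ccccc1-n1nncc1CN1C(=O)C2(C(C#N)=C(N)Oc3c2c2nc4ccccc4nc2c2ccccc32)c2ccccc21` gives > 50000 nM, a limit of the assay rather than a number.
compound 2 `CCOc1ccc(-n2nncc2CN2C(=O)C3(C(C#N)=C(N)Oc4c3c3nc5ccccc5nc3c3ccccc43)c3ccccc32)cc1` gives > 50000 nM, likewise a limit.
compound 3 `COc1ccccc1-n1nncc1CN1C(=O)C2(C(C#N)=C(N)Oc3c(N)cc4nc5ccccc5nc4c32)c2ccccc21` gives > 50000 nM, also a limit.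

All three sit at the limit of > 50000 nM in this assay, at which 3 of the 3 values shown sit, in this assay. The change 4-ethoxyphenyl in place of 2-methoxyphenyl on an aromatic nitrogen from compound 1 to compound 2 produces a step that the two limits leave unreadable from compound 1 to compound 2. Compound 1 and compound 3 have different cores; that difference is not broken down here. Compound 4 `CCOc1ccc(-n2nncc2CN2C(=O)C3(C(C#N)=C(N)Oc4c(N)cc5nc6ccccc6nc5c43)c3ccccc32)cc1` has not yet been measured; it is made from compound 3 by the same change, (4-ethoxyphenyl in place of 2-methoxyphenyl on an aromatic nitrogen). Because compound 1, compound 2 and compound 3 all rest at the limit of > 50000 nM in this assay, at which 3 of the 3 values shown sit, compound 4 is expected to stay there too, with an expected step that the limit leaves unreadable from compound 3 to compound 4. Compound 4 is therefore estimated at 80000 nM, most likely between 30000 nM and 300000 nM, and most probably reported only as a limit.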

Compound 4, half-maximal inhibitory concentration: > 50000 nM
Compound 4 was reported as a limit; the forecaster's own chance of this, stated with the estimate: 90%; the middle value is on the limit's open side.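

Among the compounds shown here, compound 3 and compound 4 are both reported only as limits, so no step between them can be read. The compounds shown leave open whether replacing 2-methoxyphenyl with 4-ethoxyphenyl alters antiproliferative activity at all.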